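Swapping the Halogenated Aryl Group: Compound 3 to Compound 4

The source may report more compounds than this note shows. Statements on the series, on what has been measured and on what is new or still open speak of the compounds shown alone.

Compound 1, `CCCN(CC1CC1)C(=O)c1sc(Nc2c(Cl)cc(Cl)cc2Cl)nc1C`: 360 nM
Compound 2, `CCCN(Cc1sc(Nc2c(Cl)cc(Cl)cc2Cl)nc1C)CC1CC1`: no result reported
Compound 3, `CCCN(Cc1sc(Nc2c(C)cc(Cl)cc2Cl)nc1C(F)(F)F)CC1CC1`: 16 nM

In an assay for displacement of a labelled ligand from corticotropin-releasing factor receptor 1 (Homo sapiens) (a higher number here means a weaker inhibitor, a lower number a stronger inhibitor), compound 3 gives 16 nM, the lowest of the two numbers reported. The nearest is compound 1, which in this assay gives 360 nM, a higher number, and this gap lies beyond the usual scatter. For compound 2 in this assay the outcome is no result reported.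

Compound 4, `CCCN(Cc1sc(Nc2c(Br)cc(C)cc2Br)nc1C(F)(F)F)CC1CC1`, differs from compound 3 in one place: 2,6-dibromo-4-methylphenyl in place of 2,4-dichloro-6-methylphenyl on a nitrogen on an aromatic ring. Going by the values given here, no measured pair shows this exchange, so the size of its effect is not known from these data. Compound 4 is expected to behave much like compound 3, with an estimated step of a 1.3-fold higher number from compound 3 to compound 4 (0.10 log units; within the scatter) that stays within the scatter. Compound 4 is therefore estimated at 20 nM, in a range from 6 nM to 60 nM.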

Compound 4, inhibition constant: 28 nM
Compound 4: the middle estimate sits 1.4-fold (0.15 log units) below what was measured, within the range that was stated.
By their numbers in this assay, from the lowest: compounds 3 and 4 (each within the scatter of the next); then compound 1.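

In this assay, going by these compounds alone, the first measured pair that differs only in this aryl group on the nitrogen gives a 1.8-fold higher number from compound 3 to compound 4 (0.24 log units; within the scatter). At this place, then, 2,6-dibromo-4-methylphenyl and 2,4-dichloro-6-methylphenyl cannot be told apart in this assay. No supporting data bear on why this is so.

From the compounds shown here alone, this single exchange alters both the halogen and the arrangement of the groups on the ring, so their separate contributions remain unknown. Also open, going by these compounds, is whether an aryl group carrying a methoxy group or an amine would give a similar number.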